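The source may hold more compounds than are shown below. What is called first, only, known or untested is meant among the compounds shown, and "the series" means these compounds.

Working notes on the series. Compound 1 `C=C1CC[C@@H]2[C@](C)(CNCc3ccc(F)cc3)[C@H](O)CC[C@@]2(C)[C@@H]1/C=C/C1=CCOC1=O` and compound 2 `C=C1CC[C@@H]2[C@](C)(CNCc3nccs3)[C@H](O)CC[C@@]2(C)[C@@H]1/C=C/C1=CCOC1=O` share one core and differ only in the group on the saturated chain carbon bound to the amine nitrogen. In a functional assay on BMMC cells (Mus musculus, strain C57BL/6) for inhibition, with stated times of 5 days and 48 h (a lower number here means a stronger inhibitor, a higher number a weaker inhibitor), compound 1 gives 350 nM, and compound 2 gives 700 nM. Among the compounds with values here, the single step measured so far, a 2.0-fold higher number from compound 1 to compound 2 (0.30 log units; within the scatter), is within the scatter, so the two compounds cannot be ordered. Compound 2 thus holds the higher of the two numbers, with compound 1 within the scatter of it.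

Compound 3 `C=C1CC[C@H]2[C@@](C)(CC[C@@H](O)[C@@]2(C)C(=O)NCc2ccc(Br)cc2)[C@@H]1/C=C/C1=CCOC1=O` is not yet measured. Relative to compound 2 the change is (4-bromobenzyl)carbamoyl in place of (((1,3-thiazol-2-yl)methyl)amino)methyl on a saturated ring carbon. Within the data shown here, no measured step bears on an exchange of the amine-bearing chain for a carbamoyl group; the only step, from a 4-fluorophenyl to a 1,3-thiazol-2-yl group, was within the scatter, which gives no direction for compound 3. The expectation for compound 3 in this assay is therefore a number near that of compound 2, with a wide range: an estimated 800 nM (range 200 nM to 3500 nM), meaning an expected step of a 1.1-fold higher number from compound 2 to compound 3 (0.06 log units; within the scatter).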

Compound 3, half-maximal inhibitory concentration: 3450 nM
Compound 3: middle estimate off by 4.3-fold (0.63 log units), on the low side; measured number inside the range.
By their numbers in this assay, from the lowest: compounds 1 and 2 (each within the scatter of the next); then compound 3.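

In this assay the exchange of the amine-bearing chain for (4-bromobenzyl)carbamoyl on the saturated ring carbon gives a 4.9-fold higher number from compound 2 to compound 3 (0.69 log units; beyond the scatter) and a 9.9-fold higher number from compound 1 to compound 3 (0.99 log units; beyond the scatter). Unlike the exchange of the terminal group between the two amine-bearing compounds, this change gives steps beyond the scatter, so the number at this position does respond to the chain, and it goes up from both amine-bearing compounds. Nothing measured here explains this rise.

From the compounds shown here alone, the carbamoyl link and the 4-bromobenzyl group enter together, so it remains open which of them carries the step: a 4-bromobenzylamine chain or a (4-fluorobenzyl)carbamoyl group would separate the two. Also open, going by these compounds, is how a carboxylic acid or a longer amine chain on this carbon would read in this assay.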